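Swapping the Carbamoyl for a Piperidinylmethyl Side Chain

The source may report more compounds than this note shows. Statements on the series, on what has been measured and on what is new or still open speak of the compounds shown alone.

Compound 1 `[N-]=[N+]=NCC(O)Cn1c(=O)n(C2OC(CO)[C@@H](O)[C@H]2O)c2nc(N)nc(O)c21`: 91%
Compound 2 `N#Cc1cccc(Cn2c(=O)n(C3OC(CO)[C@@H](O)[C@H]3O)c3nc(N)nc(O)c32)c1`: 16%
Compound 3 `NC(=O)Cn1c(=O)n(C2OC(CO)[C@@H](O)[C@H]2O)c2nc(N)nc(O)c21`: 32%

In a functional assay on the whole organism (B cells) with Mus musculus as the target (a lower number here means a smaller maximal response, a higher number a larger maximal response), compound 3 gives 32%, the second highest of the three numbers: compound 1 stands well above it, compound 2 below it. The unmeasured compound 4 `Nc1nc(O)c2c(n1)n(C1OC(CO)[C@@H](O)[C@H]1O)c(=O)n2CCN1CCCCC1` differs from compound 3 only at the saturated chain carbon bound to an aromatic nitrogen: (piperidin-1-yl)methyl in place of carbamoyl on a saturated chain carbon bound to an aromatic nitrogen.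

Among the measured compounds shown here, no measured step involves the entering (piperidin-1-yl)methyl group, so nothing directly tells how it will behave. What the measured steps do show is that this position moves the read-out strongly: a number 59 percentage points lower from compound 1 to compound 3 (beyond the scatter) and a number 16 percentage points higher from compound 2 to compound 3 (beyond the scatter), while a number 75 percentage points lower from compound 1 to compound 2 (beyond the scatter). Three different groups here span most of the observed range, so a large shift in either direction is possible for compound 4, but its direction cannot be read from the steps at hand.

For compound 4, the estimate is therefore a value near the middle of the measured spread, 45%, with a wide range from 15% to 85%. This implies an expected step of a number 13 percentage points higher from compound 3 to compound 4 (beyond the scatter), which is not a confident prediction of change beyond the scatter.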

Compound 4, largest response reached (reported as maximal response), in percent of the reference or control that the assay uses: 0%
Compound 4: middle estimate off by 45 percentage points, on the high side; the whole stated range lies above it.
By their numbers in this assay, from the lowest: compound 4; then compound 2; then compound 3; then compound 1.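

In this assay, (piperidin-1-yl)methyl on the saturated chain carbon bound to an aromatic nitrogen shows that this position can go lower than any earlier group did, with a number 32 percentage points lower from compound 3 to compound 4 (beyond the scatter) and, against the previous lowest compound, a number 16 percentage points lower from compound 2 to compound 4 (beyond the scatter). Among the compounds shown here, with a number 91 percentage points lower from compound 1 to compound 4 (beyond the scatter), the range at this one place now runs from compound 4 at 0% to compound 1 at 91%, and the two groups that carry a ring, in compound 2 and compound 4, stand lowest, with no compound among the four going against this. Nothing measured here speaks to what lies behind the drop.

On these data alone, whether the low number goes with the ring or with the nitrogen of the (piperidin-1-yl)methyl group stays open, and a morpholine ring or an open-chain diethylamino group on the same chain would help to separate the two. Also open, as far as these compounds go, is how a carboxylic acid in place of the carbamoyl, or a longer chain between the ring and the core, would behave.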